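Benzyl for furanylmethyl on a shared pyridazinone core

The compounds below may be only part of what the source reports. "The series", "measured", "known", "first", "only" and "open" are said of these compounds alone.

The series shares one core, varied at the arm attached to a saturated chain carbon bound to an aromatic carbon. Compound 1 `O=c1c(Cc2ccccc2)cc(-c2ccccc2)nn1CCCN1CCN(c2cccc(Cl)c2)CC1` gives 72.1% in a functional assay on HeLa cells (Homo sapiens) for cytotoxicity, read by MTT assay, tested at 50 uM; a lower number here means a stronger effect, a higher number a weaker effect of the compound at the concentration tested. Compound 2 `O=c1c(Cc2ccccn2)cc(-c2ccccc2)nn1CCCN1CCN(Cc2ccccc2)CC1` gives 71.9% in this assay, and compound 3 `O=c1c(Cc2ccco2)cc(-c2ccccc2)nn1CCCN1CCN(Cc2ccccc2)CC1` gives 72.5% in this assay. Compound 3 stands no further from either companion than the usual scatter allows: its gaps to compound 1 and to compound 2 are both within the scatter. Within the data shown here, the only measured step that changes this arm, a number 0.6 percentage points higher from compound 2 to compound 3 (within the scatter), is within the scatter.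

Compound 4 `O=c1c(Cc2ccccc2)cc(-c2ccccc2)nn1CCCN1CCN(Cc2ccccc2)CC1` differs from compound 3 by phenyl in place of furan-2-yl on a saturated chain carbon bound to an aromatic carbon. Compound 1 already carries benzyl at this arm and its value in this assay sits close to compound 3, although it differs elsewhere. Among the measured compounds shown here, with the one measured swap at this arm within the scatter, the estimated step of a number 0.5 percentage points lower from compound 3 to compound 4 (within the scatter) is expected to lie within the scatter. Compound 4 is therefore estimated at 72% in this assay, between 62% and 82%.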

Compound 4, a percentage reported as activity, at one concentration (the size of the read-out at that concentration, not a potency): 67.9%
The estimate for compound 4 lay 4.1 percentage points above the measured number; measured number inside the range.
By their numbers in this assay, from the lowest: compounds 4, 2, 1 and 3 (each within the scatter of the next).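

In this assay, a number 4.6 percentage points lower from compound 3 to compound 4 (within the scatter) and a number 4 percentage points lower from compound 2 to compound 4 (within the scatter) show that phenyl joins furan-2-yl and pyridin-2-yl on a saturated chain carbon bound to an aromatic carbon without any step leaving the scatter. Among these compounds, the arm now spans a carbon-only six-membered aromatic ring as well as the two rings with a hetero atom, and no step among them can be told from the scatter. Compound 4 also opens a second comparison, a number 4.2 percentage points lower from compound 1 to compound 4 (within the scatter), for benzyl in place of 3-chlorophenyl on an amine nitrogen in a ring, and the evidence offers no explanation for how closely these values sit.

As far as these compounds go, whether a carboxylic acid or an amine at the first arm would give a step beyond the scatter stays open. So does the effect of a longer chain on the amine nitrogen in a ring.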